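The source may report more compounds than this note shows. Statements on the series, on what has been measured and on what is new or still open speak of the compounds shown alone.

Measured in a functional assay on SK-N-MC cells (Homo sapiens) for inhibition, read by cAMP accumulation; a lower number here means a stronger inhibitor, a higher number a weaker inhibitor:
Compound 1 `Clc1ccc(OCc2nc3c(OCCC4CCNCC4)cccc3n2CCCC2CCCNC2)cc1`: 15 nM
Compound 2 `Clc1ccc(OCc2nc3c(OCCC4CCCNC4)cccc3n2CCCC2CCCNC2)cc1`: 91 nM

Among the measured compounds shown here, compound 2 has the higher of the two numbers, and the only measured step is a 6.1-fold higher number from compound 1 to compound 2 (0.78 log units; beyond the scatter), which places piperidin-3-yl where piperidin-4-yl stood. Compound 3 `Clc1ccc(OCc2nc3c(OCCCC4CCNCC4)cccc3n2CCCC2CCCNC2)cc1` has not yet been measured. Its difference from compound 2 is (piperidin-4-yl)methyl in place of piperidin-3-yl on a saturated chain carbon, two bonds along the chain from an oxygen on an aromatic ring, with (piperidin-4-yl)methyl in place of piperidin-3-yl on a saturated chain carbon, two bonds along the chain from an oxygen on an aromatic ring. For the measured compounds named here, compound 3 thus carries piperidin-4-yl again, as compound 1 does, but as 3-(piperidin-4-yl)propoxy, and no measured step covers that chain. Going by the values given here, the step of a 6.1-fold higher number from compound 1 to compound 2 (0.78 log units; beyond the scatter) is therefore the only guide, and a change of similar or somewhat smaller size in the opposite direction is expected. The expected step is a 3.6-fold lower number from compound 2 to compound 3 (0.56 log units; beyond the scatter). The estimate for compound 3 is 25 nM, with an estimated range from 8 nM to 80 nM.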

Compound 3, inhibition constant: 119 nM
Compound 3: the middle estimate sits 4.8-fold (0.68 log units) below what was measured; the whole stated range lies below it.
By their numbers in this assay, from the lowest: compound 1; then compounds 2 and 3 (each within the scatter of the next).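

In this assay the piperidin-4-yl ring alone does not secure the low number of compound 1: on the longer 3-(piperidin-4-yl)propoxy chain the result is a 7.9-fold higher number from compound 1 to compound 3 (0.90 log units; beyond the scatter) and so chain length at this position counts as well as the ring attachment. The change from 2-(piperidin-3-yl)ethoxy to 3-(piperidin-4-yl)propoxy gives a 1.3-fold higher number from compound 2 to compound 3 (0.12 log units; within the scatter) and so compound 2 and compound 3 stand level, with compound 1 the strongest inhibitor of the three. Nothing available explains why either change has the effect it does.

The compounds shown leave open how a shorter (piperidin-4-yl)methoxy chain or a 3-(piperidin-3-yl)propoxy chain would read, the latter pairing the longer chain with the other ring attachment. They also leave open whether an N-methylpiperidine or a piperazine in place of piperidin-4-yl would keep the number of compound 1.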